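Replacing 3-chloro-4-fluorobenzyl with 2,3-dihydroxybenzyl

A few compounds are considered here, and "the series" means these few. Any claim that something is new, unique, unknown or untested is made for them only; others in the source may bear on it.

Compound 1 `OC[C@H]1O[C@@H](n2cnc3c(NCc4ccccc4F)ncnc32)[C@H](O)[C@@H]1O`: > 166000 nM, a limit
Compound 2 `OC[C@H]1O[C@@H](n2cnc3c(NCc4ccc(Cl)c(Cl)c4)ncnc32)[C@H](O)[C@@H]1O`: 88800 nM
Compound 3 `OC[C@H]1O[C@@H](n2cnc3c(NCc4ccc(F)c(Cl)c4)ncnc32)[C@H](O)[C@@H]1O`: > 166000 nM, a limit

All three results come from a functional assay on MCF cells (Homo sapiens) for antiproliferative activity, with a stated time of 72 h; a higher number here means a weaker inhibitor, a lower number a stronger inhibitor. Compound 3 gives only a limit, > 166000 nM. This is the limit of > 166000 nM in this assay, at which 2 of the 3 values shown sit.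

In compound 4 `OC[C@H]1O[C@@H](n2cnc3c(NCc4cccc(O)c4O)ncnc32)[C@H](O)[C@@H]1O`, 2,3-dihydroxyphenyl takes the place of 3-chloro-4-fluorophenyl on a saturated chain carbon bound to a nitrogen on an aromatic ring: 2,3-dihydroxyphenyl in place of 3-chloro-4-fluorophenyl on a saturated chain carbon bound to a nitrogen on an aromatic ring.

Going by the values given here, no measured compound carries hydroxy groups on this ring, so the evidence is indirect. The nearest measured changes are an at least 1.8-fold lower number from compound 1 to compound 2 (0.27 log units; that floor lies within the scatter) and an at least 1.8-fold higher number from compound 2 to compound 3 (0.27 log units; that floor lies within the scatter), and both floors stay within the scatter. The third comparison is a step that the two limits leave unreadable from compound 1 to compound 3.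

Among the compounds with values here, the only true number in this set is that of compound 2 at 88800 nM, so compound 4 is expected to lie near that value. The expected change is an at least 1.3-fold lower number from compound 3 to compound 4 (0.14 log units; that floor lies within the scatter), and a report of only a limit would be unsurprising. In this assay, compound 4 is estimated at 120000 nM, with an expected range of 40000 nM to 300000 nM.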

Compound 4, half-maximal inhibitory concentration: 5200 nM
Beside the measured number, compound 4's estimate is 23-fold (1.36 log units) above it; measured number outside the range, below it.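

In this assay, going by these compounds alone, the 2,3-dihydroxyphenyl group gives the first clear separation in this set: the change reads a 17-fold lower number from compound 2 to compound 4 (1.23 log units; beyond the scatter) and rests on two true numbers, whereas the earlier steps among the halogenated rings stayed within the scatter or could not be read. Against the other two neighbours the change reads an at least 31-fold lower number from compound 3 to compound 4 (1.50 log units; beyond the scatter) and an at least 31-fold lower number from compound 1 to compound 4 (1.50 log units; beyond the scatter) and gives only floors, because compound 1 and compound 3 each stand at a limit: the limit of > 166000 nM in this assay, at which 2 of the 4 values shown sit. At this place, on a saturated chain carbon bound to a nitrogen on an aromatic ring, the substituents on the phenyl ring can therefore move the number well beyond the scatter.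

The compounds shown leave open whether both hydroxy groups are needed, or whether a single hydroxy, a methoxy or an amine would serve as well. Because the halogens leave and the hydroxy groups enter at different ring positions in one step, the contribution of each remains unresolved.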